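Series notes: benzyl in place of pyridinylmethyl on the amine

The source may hold more compounds than are shown below. What is called first, only, known or untested is meant among the compounds shown, and "the series" means these compounds.

Compound 1, `Clc1cc(Cl)cc(CO[C@H]2CCCN(Cc3ccncc3)[C@H]2c2ccccc2)c1`: in an assay on isolated protein for activation of cGMP-dependent protein kinase 1 (Homo sapiens), read by ADP-Glo, with stated times of 120 min and 40 min (on this read-out lower numbers stand for an effect already at smaller amounts and higher numbers for an effect only at larger amounts of compound), compound 1 gives > 200000 nM, which is a limit of the assay, not a number.
Compound 2, `Clc1cc(Cl)cc(CO[C@H]2CCCN(Cc3ccccn3)[C@H]2c2ccccc2)c1`: in this assay compound 2 gives > 200000 nM, again a limit of the assay.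
Compound 3, `COC(=O)Nn1c(C[C@H]2CCC[C@H](OCc3cc(C(F)(F)F)cc(C(F)(F)F)c3)[C@@H]2c2ccccc2)n[nH]c1=O`: in this assay compound 3 gives 4500 nM.

Going by the values given here, compound 1 thus stands only at a limit in this assay; no number is known for it, and compound 2 shares the same position, so the only step measured within the shared core, a step that the two limits leave unreadable from compound 1 to compound 2, cannot be read in size or direction. Compound 3 carries a different core and different ring substituents, so its value is not directly comparable with the step considered here.

The unmeasured compound 4, `Clc1cc(Cl)cc(CO[C@H]2CCCN(Cc3ccccc3)[C@H]2c2ccccc2)c1`, differs from compound 1 as follows: phenyl in place of pyridin-4-yl on a saturated chain carbon bound to an amine nitrogen in a ring. Among the compounds with values here, no measured step bears on this change beyond the fact given by the limit of > 200000 nM in this assay, at which 2 of the 3 values shown sit. With compound 1 at a limit in this assay, the step of a number no higher from compound 1 to compound 4 (the limit leaves the size open) is expected to stay unreadable, most likely ending at the limit again. Compound 4 is therefore estimated at 200000 nM in this assay, with a range from 50000 nM to 500000 nM.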

Compound 4, half-maximal effective concentration: > 200000 nM
Compound 4 gave a limit, no number; the forecaster's own chance of this, stated with the estimate: 65%; the middle value lies on the limit itself.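

In this assay compound 4 sits at a limit of the assay, as do compound 1 and compound 2, so no step among these three compounds can be read in size or direction: the limit of > 200000 nM in this assay, at which 3 of the 4 values shown sit.

The compounds shown leave open whether phenyl, pyridin-4-yl or pyridin-2-yl makes any difference on the shared core, which has no numerical value here.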